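This account rests on a few compounds, and the source may have more. Where it says the series, first, only, none or still open, it means among the compounds named here.

Of the compounds shown here, three built on one shared core have been tested in an assay on isolated protein for inhibition of malate dehydrogenase, mitochondrial (Sus scrofa), with stated times of 45 min and 30 min; a higher number here means a weaker inhibitor, a lower number a stronger inhibitor. Compound 1 `O=S(=O)(Nc1ccc2oc(-c3ccccc3)nc2c1)c1cccc(F)c1` carries a 3-fluorophenyl on the sulfonyl sulfur, and in this assay compound 1 gives > 63000 nM, which is a limit of the measurement and not a number. Compound 2 `O=S(=O)(Nc1ccc2oc(-c3ccccc3)nc2c1)c1ccccc1Cl` carries a 2-chlorophenyl there, and in this assay compound 2 also gives only the limit > 63000 nM. Compound 3 `O=S(=O)(Nc1ccc2oc(-c3ccccc3)nc2c1)c1cccs1` carries a thiophen-2-yl, and in this assay compound 3 gives the limit > 63000 nM. Compound 3 thus stands where both others stand, as shown by the limit of > 63000 nM in this assay, at which 3 of the 3 values shown sit. The steps a step that the two limits leave unreadable from compound 1 to compound 2, a step that the two limits leave unreadable from compound 1 to compound 3 and a step that the two limits leave unreadable from compound 2 to compound 3 cannot be sized. Compound 4 `COc1ccc(Cl)cc1S(=O)(=O)Nc1ccc2oc(-c3ccccc3)nc2c1` differs from compound 3 by 5-chloro-2-methoxyphenyl in place of thiophen-2-yl on a sulfonyl sulfur. Every step among the measured compounds is unreadable, so none gives a size for this change. Compound 4 is expected to remain at the limit as well, an expected step that the limit leaves unreadable from compound 3 to compound 4. The estimate for compound 4 in this assay is 100000 nM, within 30000 nM to 400000 nM.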

Compound 4, half-maximal inhibitory concentration: > 63000 nM
Compound 4: a limit, no number; the forecaster's own chance of this, stated with the estimate: 85%; the middle value is on the limit's open side.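

Within the data shown here, compound 4 also gives only a limit, so no step from compound 1, compound 2 or compound 3 to compound 4 can be read, and all four compounds stand together: the limit of > 63000 nM in this assay, at which 4 of the 4 values shown sit. The compounds shown leave open whether any group on the sulfonyl sulfur of the shared core gives a measurable value in this assay.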